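The source may report more compounds than this note shows. Statements on the series, on what has been measured and on what is new or still open speak of the compounds shown alone.

Three compounds built on one shared core were tested in a functional assay on A549 cells (Homo sapiens) for cytotoxicity, read by MTT assay, with a stated time of 24 h, tested at 40 uM; a higher number here means a weaker effect of the compound at the concentration tested, a lower number a stronger effect. Compound 1 `CCCCOC(=O)CCC(=O)N1CCN(CCCOc2cc3c(Nc4ccc(F)c(Cl)c4)ncnc3cc2OC)CC1` gives 79.1%. Compound 2 `CCCCCCCCCOC(=O)CCC(=O)N1CCN(CCCOc2cc3c(Nc4ccc(F)c(Cl)c4)ncnc3cc2OC)CC1` gives 17.9%, and compound 3 `CCCCCCCCCCOC(=O)CCC(=O)N1CCN(CCCOc2cc3c(Nc4ccc(F)c(Cl)c4)ncnc3cc2OC)CC1` gives 15.5%. On these numbers compound 3 stands lowest of the three, though its gap to compound 2 lies within the scatter; only its gap to compound 1 is beyond it. Two steps were large: a number 61.2 percentage points lower from compound 1 to compound 2 (beyond the scatter) and a number 63.6 percentage points lower from compound 1 to compound 3 (beyond the scatter). The third was small: a number 2.4 percentage points lower from compound 2 to compound 3 (within the scatter).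

Compound 4 `CCCCCCCCCCCCOC(=O)CCC(=O)N1CCN(CCCOc2cc3c(Nc4ccc(F)c(Cl)c4)ncnc3cc2OC)CC1` is the next member of the series. Its change from compound 3 is ethyl in place of hydrogen on a saturated chain carbon, ten or more bonds along the chain from an oxygen next to a carbonyl group. The measured step that bears most directly on this one also lengthened the same chain, by a methyl, and read a number 2.4 percentage points lower from compound 2 to compound 3 (within the scatter), a difference within the scatter. The large drops came only when the short chain of compound 1 was lengthened substantially; once the chain is already long, a further small lengthening showed no effect beyond the scatter. Compound 4 is therefore expected to show a number 1.5 percentage points lower from compound 3 to compound 4 (within the scatter), no change beyond the scatter. The estimate for compound 4 in this assay is 14%, with a range from 6% to 25%.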

Compound 4, a percentage reported as activity, at one concentration (the size of the read-out at that concentration, not a potency): 5.7%
Compound 4: the middle estimate sits 8.3 percentage points above what was measured; the measured number lies below the stated range.
By their numbers in this assay, from the lowest: compounds 4, 3 and 2 (each within the scatter of the next, the first and the last beyond it); then compound 1.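

In this assay, ethyl in place of hydrogen on a saturated chain carbon gives a number 9.8 percentage points lower from compound 3 to compound 4 (within the scatter), so this change alone cannot be told apart from the usual noise. Among the compounds shown here, the comparison across two chain extensions says more: propyl in place of hydrogen gives a number 12.2 percentage points lower from compound 2 to compound 4 (beyond the scatter), the only step among the three long-chain compounds that clears the scatter, so the read-out had not fully settled at compound 2. Octyl in place of hydrogen gives a number 73.4 percentage points lower from compound 1 to compound 4 (beyond the scatter), the widest step among the four compounds, though most of that distance was already covered by compound 2.

Still open, going by these compounds, is whether a longer chain would take the number lower, or whether an amine or a carboxylic acid at the far end of the chain would keep the effect seen with compound 4. Nothing available here gives a reason for any of these steps, so the link between chain length and the read-out remains an observation only.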